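The compounds below may be only part of what the source reports. "The series", "measured", "known", "first", "only" and "open" are said of these compounds alone.

Of the compounds shown here, three have been measured in a functional assay on BaF3 cells (Mus musculus) for inhibition, read by CCK-8 assay, with a stated time of 72 h; a higher number here means a weaker inhibitor of growth, a lower number a stronger inhibitor of growth. Compound 2 (`Cc1ccc(NC(=O)Nc2ccc(Oc3cc(N(C)CCN(C)C)ncn3)cc2)cc1C(F)(F)F`) stands highest of the three at 9410 nM, a weaker result than compound 3 (`CC(=O)Nc1cc(Oc2ccc(NC(=O)Nc3cc(-n4cnc(C)c4)cc(C(F)(F)F)c3)cc2)ncn1`) at 1320 nM and compound 1 (`CCN1CCN(Cc2ccc(NC(=O)Nc3ccc(Oc4cc(NC(C)=O)ncn4)cc3)cc2C(F)(F)F)CC1`) at 38 nM. Compound 4 (`Cc1ccc(NC(=O)Nc2ccc(Oc3cc(NCCO)ncn3)cc2)cc1C(F)(F)F`) keeps the rest of compound 2 and changes one group on an aromatic carbon of a six-membered aromatic ring with 2 nitrogen: (2-hydroxyethyl)amino in place of (2-(dimethylamino)ethyl)(methyl)amino on an aromatic carbon. For the measured compounds named here, no two measured compounds differ in one place only, so no measured step gives the size of this change. Compound 1 and compound 3 both lie lower than compound 2, but each also differs from it elsewhere, so neither isolates this group. A modest fall in this assay is therefore expected, and a result within the scatter of compound 2 would be no surprise. The expected change is a 2.1-fold lower number from compound 2 to compound 4 (0.32 log units; beyond the scatter). For compound 4 the estimated value is 4500 nM, with an expected range from 1000 nM to 20000 nM.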

Compound 4, concentration for 50% growth inhibition: > 10000 nM
Compound 4: only a limit was reported; the forecaster's own chance of this, stated with the estimate: 15%; at least 2.2-fold (0.34 log units) between middle value and limit.
By their numbers in this assay, from the lowest: compound 1; then compound 3; then compound 2. At a limit, above all of these: compound 4.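

In this assay compound 4 gives > 10000 nM, which is a limit of the assay and not a number. For the compounds shown here, this gives the first comparison in the set that differs in one place only, an at least 1.0-fold higher number from compound 2 to compound 4 (0.02 log units; that floor lies within the scatter), so putting (2-hydroxyethyl)amino in place of (2-(dimethylamino)ethyl)(methyl)amino on this aromatic carbon brought no fall in the number, although the floor of this step lies within the scatter. The reading of this change therefore stops at the top of what the assay reports: the limit of > 10000 nM in this assay, at which 1 of the 4 values shown sits.

Going by these compounds, how far the true value of compound 4 lies beyond its limit remains open, and so does the full size of the change. Also open, on these data alone, is whether another group at this position, such as a morpholine, a primary amine or a carboxylic acid, would lower the number.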